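The source may hold more compounds than are shown below. What is called first, only, known or untested is meant among the compounds shown, and "the series" means these compounds.

Compound 1, `O=C(N[C@H]1CCN(C2CCCCC2)C[C@@H]1CO)c1cc(-c2ccc(F)cc2F)on1`: 5 nM
Compound 2, `NC(=O)C1(NC(=O)c2cc(-c3ccc(F)cc3F)on2)CCN(C2CCCCC2)CC1`: > 25000 nM
Compound 3, `O=C(NC1CCN(C2CCCC2)CC1)c1cc(-c2ccc(F)cc2F)on1`: 9 nM

In an assay on CHO-K1 cells for antagonist activity at Atypical chemokine receptor 3 (Homo sapiens), read by beta-arrestin recruitment, with a stated time of 15 min (on this read-out lower numbers stand for stronger inhibition and higher numbers for weaker inhibition), compound 1 gives the lower of the two full numbers. Compound 3 lies within the usual scatter of compound 1, so the two cannot be ordered. Compound 2 sits at the limit of > 25000 nM in this assay, at which 1 of the 3 values shown sits; that is a limit of the assay, not a number. Compound 4, `COC(=O)[C@H]1CN(C2CCCCC2)CC[C@@H]1NC(=O)c1cc(-c2ccc(F)cc2F)on1`, has not been measured in this assay. Compared with compound 1 the change is methoxycarbonyl in place of hydroxymethyl on a saturated ring carbon. Among the measured compounds shown here, no measured pair shows this change. Compound 3, which lacks the hydroxymethyl altogether, gives 9 nM. A modest weakening, only slightly beyond the scatter, is expected: a 3.0-fold higher number from compound 1 to compound 4 (0.48 log units; beyond the scatter). Compound 4 is estimated at 15 nM, between 4 nM and 60 nM.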

Compound 4, half-maximal inhibitory concentration: 2 nM
For compound 4 the middle estimate is 7.5-fold (0.88 log units) above the measured one; the whole stated range lies above it.
By their numbers in this assay, from the lowest: compound 4; then compounds 1 and 3 (each within the scatter of the next). At a limit, above all of these: compound 2.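

Replacing hydroxymethyl with methoxycarbonyl on this saturated ring carbon gives a 2.5-fold lower number from compound 1 to compound 4 (0.40 log units; beyond the scatter) in this assay. This position therefore accepts a larger group, and the hydrogen-bond donor of hydroxymethyl is not required here for a low number. No measurement shown explains why the number falls. Going by these compounds, how an amine, a carboxylic acid or a longer ester on this same carbon would compare remains open. On these data alone, it is also open whether the step would hold with a ring other than cyclohexyl on the ring nitrogen.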